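Ethoxy Replaces 4-Fluorophenyl on the Benzylidene Ring

The source may report more compounds than this note shows. Statements on the series, on what has been measured and on what is new or still open speak of the compounds shown alone.

Compound 2 `CC(C)=CCOc1c(C)c(C)c2c(c1C)CCC(C)(COc1ccc(/C=C3\SC(=O)NC3=O)cc1-c1ccc(F)cc1)O2` gives 92% in a functional assay on MCF7 cells (Homo sapiens), tested at 5 uM (a higher number here means a weaker effect of the compound at the concentration tested, a lower number a stronger effect), the higher of the two numbers measured, with compound 1 `CC(C)=CCOc1c(C)c(C)c2c(c1C)CCC(C)(COc1ccc(/C=C3\SC(=O)NC3=O)cc1C)O2` giving 56%. Going by the values given here, the one known step, a number 36 percentage points higher from compound 1 to compound 2 (beyond the scatter), bears on the change to compound 3 `CCOc1cc(/C=C2\SC(=O)NC2=O)ccc1OCC1(C)CCc2c(C)c(OCC=C(C)C)c(C)c(C)c2O1` only in reverse: ethoxy in place of 4-fluorophenyl on an aromatic carbon. Because that step was a number 36 percentage points higher from compound 1 to compound 2 (beyond the scatter), removing the 4-fluorophenyl is expected to move the number back toward that of compound 1, so compound 3 is estimated to show a number 26 percentage points lower from compound 2 to compound 3 (beyond the scatter). Compound 3 is therefore estimated at 66%, within 45% to 90%.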

Compound 3, a percentage reported as activity, at one concentration (the size of the read-out at that concentration, not a potency): 84%
Estimate against measurement, compound 3: 18 percentage points below, within the range that was stated.
By their numbers in this assay, from the lowest: compound 1; then compounds 3 and 2 (each within the scatter of the next).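

In this assay, ethoxy in place of 4-fluorophenyl leaves the number within the scatter (a number 8 percentage points lower from compound 2 to compound 3 (within the scatter)), whereas ethoxy in place of methyl does not (a number 28 percentage points higher from compound 1 to compound 3 (beyond the scatter)). Among the three groups shown at this position, methyl alone stands apart, and an aromatic ring in the substituent is not needed for the higher number, since ethoxy has no ring. No evidence is available to explain this result.

From the compounds shown here alone, whether a hydroxyl, an amine or a carboxylic acid here would align with methyl or with ethoxy remains open. So does the outcome for a longer chain such as butoxy.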